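Replacing 3-fluorophenyl with 2-nitrophenyl on the saturated ring carbon

A few compounds are considered here, and "the series" means these few. Any claim that something is new, unique, unknown or untested is made for them only; others in the source may bear on it.

In a functional assay on MCF7 cells (Homo sapiens) for antiproliferative activity, read by MTT assay, with a stated time of 48 h (on this read-out higher numbers stand for weaker inhibition and lower numbers for stronger inhibition), compound 1 `CC(=O)N1N=C(c2ccc3ccccc3c2)OC1c1ccccc1` gives 2.43 ug/mL, compound 2 `COc1ccc(C2OC(c3ccc4ccccc4c3)=NN2C(C)=O)cc1` gives 7.35 ug/mL and compound 3 `CC(=O)N1N=C(c2ccc3ccccc3c2)OC1c1cccc(F)c1` gives 1.98 ug/mL. Compound 3 stands within the scatter of compound 1 and clear of compound 2, with a 3.7-fold lower number from compound 2 to compound 3 (0.57 log units; beyond the scatter). Compound 4 `CC(=O)N1N=C(c2ccc3ccccc3c2)OC1c1ccccc1[N+](=O)[O-]` has 2-nitrophenyl in place of 3-fluorophenyl on a saturated ring carbon. Going by the values given here, two measured steps bear on this change. The fluoro step, a 1.2-fold lower number from compound 1 to compound 3 (0.09 log units; within the scatter), stays within the scatter, while the methoxy step, a 3.0-fold higher number from compound 1 to compound 2 (0.48 log units; beyond the scatter), is modest. Neither tests a nitro group, so only a modest move toward higher numbers is expected in this assay. The estimated step is a 2.0-fold higher number from compound 3 to compound 4 (0.31 log units; beyond the scatter). The expected value for compound 4 is 4 ug/mL, with an estimated range of 1.5 ug/mL to 10 ug/mL.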

Compound 4, half-maximal inhibitory concentration: 18.2 ug/mL
The estimate for compound 4 lay 4.6-fold (0.66 log units) below the measured number; measured number above the stated range.
By their numbers in this assay, from the lowest: compounds 3 and 1 (each within the scatter of the next); then compound 2; then compound 4.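

In this assay the 2-nitrophenyl group produces the largest rise at this saturated ring carbon, with a 9.2-fold higher number from compound 3 to compound 4 (0.96 log units; beyond the scatter) and a 7.5-fold higher number from compound 1 to compound 4 (0.87 log units; beyond the scatter). Going by these compounds alone, it also stands clear of the 4-methoxyphenyl group, with a 2.5-fold higher number from compound 2 to compound 4 (0.39 log units; beyond the scatter), so this position is sensitive to the aryl substituent well beyond what the earlier steps showed. Nothing measured here explains the rise.

Open is whether the step follows the nitro group itself or its place on the phenyl ring, as the compounds shown change both at once. Going by these compounds, how an amine or a carboxylic acid on that ring would read also remains open.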